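Replacing 4-bromophenyl with quinolin-3-yl on the amide-type nitrogen

This account rests on a few compounds, and the source may have more. Where it says the series, first, only, none or still open, it means among the compounds named here.

Values in an in vivo ADME assay on the whole organism for pharmacokinetics, with Rattus norvegicus as the target; on this read-out lower numbers stand for lower oral bioavailability and higher numbers for higher oral bioavailability:
compound 1 `COc1ccc(NC(=O)c2cc(OCCCN(C)C)nn2Cc2ccccc2)cc1Cl`: 11%
compound 2 `CN(C)CCCOc1cc(C(=O)Nc2ccc(Br)cc2)n(Cc2ccccc2)n1`: 17%

For the measured compounds named here, the one measured step runs a number 6 percentage points higher from compound 1 to compound 2 (within the scatter), with 4-bromophenyl in place of 3-chloro-4-methoxyphenyl on an amide-type nitrogen. Compound 2 therefore cannot be ranked apart from compound 1.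

The next compound, compound 3 `CN(C)CCCOc1cc(C(=O)Nc2cnc3ccccc3c2)n(Cc2ccccc2)n1`, keeps the shared core and changes the group at that same place: quinolin-3-yl in place of 4-bromophenyl on an amide-type nitrogen. The entering quinolin-3-yl carries a six-membered aromatic ring with 1 hetero atom, which 4-bromophenyl lacks.

Going by the values given here, only that one earlier step bears on this change, and it stayed within the scatter. It is thin evidence, since quinolin-3-yl is a different kind of group from those already measured. No step beyond the scatter is therefore expected in this assay, in either direction, starting from compound 2 at 17%. The estimated change is small: a number 2 percentage points lower from compound 2 to compound 3 (within the scatter). The estimated value for compound 3 is 15%, with an expected range from 5% to 30%.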

Compound 3, oral bioavailability: 19%
Estimate against measurement, compound 3: 4 percentage points below, and the stated range covers the measured number.
By their numbers in this assay, from the lowest: compounds 1, 2 and 3 (each within the scatter of the next).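

In this assay, replacing the single ring of 4-bromophenyl with the two rings of quinolin-3-yl gives a number 2 percentage points higher from compound 2 to compound 3 (within the scatter), and replacing 3-chloro-4-methoxyphenyl with the same group gives a number 8 percentage points higher from compound 1 to compound 3 (within the scatter). For the compounds shown here, the earlier compounds compared only two single-ring groups, whereas this change brings 10 heavy atoms in place of 7 and adds a ring with a hetero atom and a hydrogen-bond acceptor, and the read-out still does not move beyond the scatter. On the amide-type nitrogen, all three groups therefore give numbers that cannot be told apart, and nothing available offers a cause for this result.

Going by these compounds, all three compounds carry an aromatic ring on that nitrogen, so it remains open whether a saturated group there, such as a piperidine, or a phenyl ring bearing a carboxylic acid, would produce a step beyond the scatter. The rest of the molecule is also identical across the three, which leaves open what would happen if a morpholine replaced the dimethylamino group or a longer chain carried it.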